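Ecdysone agonist series: diacylhydrazines, aryl change toward compound 4

The source may hold more compounds than are shown below. What is called first, only, known or untested is meant among the compounds shown, and "the series" means these compounds.

Measured so far in an assay on cells for agonist activity at ecdysone receptor (Bombyx mori), read by a luciferase reporter, with a stated time of 24 h; a higher number here means that more compound is needed for the effect, a lower number that less compound is needed:
compound 1, `COc1ccccc1C(=O)N(NC(=O)c1ccccc1)C(C)(C)C`: 525 nM
compound 2, `CC(C)(C)N(NC(=O)c1ccccc1)C(=O)c1ccc(Cl)cc1Cl`: 117 nM
compound 3, `CC(C)(C)N(NC(=O)c1cccc(Cl)c1)C(=O)c1ccccc1Cl`: 155 nM

Compound 3 stands second highest of the three numbers in this assay. Its nearest neighbour is compound 2, and the two values lie within the scatter of each other; compound 1 is furthest, with a number beyond the scatter above that of compound 3.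

Compound 4, `Cc1cccc(C(=O)NN(C(=O)c2ccccc2Cl)C(C)(C)C)c1C`, has not been measured. It differs from compound 3 in one place: 2,3-dimethylphenyl in place of 3-chlorophenyl on a carbonyl carbon.

Going by the values given here, only one measured step exists: a 4.5-fold lower number from compound 1 to compound 2 (0.65 log units; beyond the scatter). It also concerns an aryl group on a carbonyl carbon, but not the same carbonyl carbon as the change at hand, and it exchanges a methoxy-bearing ring for a chlorine-bearing one, while here a chlorine-bearing ring gives way to a methyl-bearing one. It therefore bears on the step only loosely. Among the compounds with values here, no measured pair speaks directly to a dimethylphenyl here, so no step beyond the scatter is expected in either direction in this assay; the estimate leans slightly toward a lower number.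

For compound 4 the estimate in this assay is 120 nM, with a range from 40 nM to 400 nM, corresponding to an expected 1.3-fold lower number from compound 3 to compound 4 (0.11 log units; within the scatter).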

Compound 4, half-maximal effective concentration: 20 nM
Beside the measured number, compound 4's estimate is 6.0-fold (0.78 log units) above it, outside the stated range (below it).
By their numbers in this assay, from the lowest: compound 4; then compounds 2 and 3 (each within the scatter of the next); then compound 1.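

In this assay the ring on this carbonyl carbon proves to be a sensitive place in the series: 2,3-dimethylphenyl in place of 3-chlorophenyl gives a 7.8-fold lower number from compound 3 to compound 4 (0.89 log units; beyond the scatter), a step beyond the scatter. Going by these compounds alone, the only step readable before, a 4.5-fold lower number from compound 1 to compound 2 (0.65 log units; beyond the scatter), lay on the other carbonyl carbon, so the earlier compounds gave no reading of this position, and this result shows that a ring carrying two methyl groups and no chlorine is not merely accepted here but gives a clearly lower number than the 3-chlorophenyl ring of compound 3. No measurement at hand accounts for the step, so it stands as an observation without an explanation.

The change replaces the chlorine and adds two methyl groups at once, so the compounds shown cannot say whether a single methyl group would carry the step or whether both methyl groups are needed. On these data alone, it also remains open whether an ethyl group, a methoxy group or an amine on this ring would hold the number, and whether the step would persist with a different ring on the other carbonyl carbon.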